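The source may report more compounds than this note shows. Statements on the series, on what has been measured and on what is new or still open speak of the compounds shown alone.

Compound 1 `Cc1ccc(-n2nc(C(=O)Nc3ccc(Oc4ncnc5sccc45)cc3)c(C)cc2=O)cc1`: > 40000 nM (a limit)
Compound 2 `Cc1cc(=O)n(-c2ccc(F)c(F)c2)nc1C(=O)Nc1ccc(Oc2ncnc3sccc23)cc1`: 13500 nM

In a functional assay on A549 cells (Homo sapiens) for cytotoxicity, read by MTT assay, with a stated time of 72 h (a higher number here means a weaker inhibitor, a lower number a stronger inhibitor), compound 1 reads > 40000 nM, which is a limit of the assay and not a number. Within the data shown here, compound 2 gives 13500 nM, the only true number so far. Among the measured compounds shown here, the sole measured step is an at least 2.9-fold lower number from compound 1 to compound 2 (0.47 log units; beyond the scatter), and it concerns the group on the aromatic nitrogen, not the place changed next. Compound 3 `Cc1cc(=O)n(-c2ccc(F)c(F)c2)nc1C(=O)Nc1ccc(Oc2ncnc3sccc23)c(F)c1` carries fluoro in place of hydrogen on an aromatic carbon, fluoro in place of hydrogen on an aromatic carbon. For the measured compounds named here, no measured step tests this change, so no shift beyond the scatter is expected. The estimated step is a 1.2-fold lower number from compound 2 to compound 3 (0.09 log units; within the scatter). For compound 3 the expected value is 11000 nM, with an estimated range of 4000 nM to 30000 nM.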

Compound 3, half-maximal inhibitory concentration: 15700 nM
The estimate for compound 3 lay 1.4-fold (0.15 log units) below the measured number; the measured number falls inside the stated range.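

In this assay the step is a 1.2-fold higher number from compound 2 to compound 3 (0.07 log units; within the scatter), so fluoro in place of hydrogen on this aromatic carbon, ortho to a large group and meta to a large group, gives no shift that can be told from the scatter. Among these compounds, the one earlier step, at the group on the aromatic nitrogen, lay beyond the scatter, whereas this change does not. Nothing shown bears on why this fluoro behaves so.

Open, going by these compounds, is how a methoxy group, an amine or a carboxylic acid on this carbon would read. Also open, on these data alone, is whether fluoro here would read alike with the 4-methylphenyl group on the aromatic nitrogen.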